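Notes on compound 4: fluoro in place of methyl

A few compounds are considered here, and "the series" means these few. Any claim that something is new, unique, unknown or untested is made for them only; others in the source may bear on it.

Measured so far:
compound 1, `COc1cc(-c2cc(C(=O)O)c3ccccc3n2)ccc1OCC(=O)Nc1ccccc1`, 0.7
compound 2, `COc1cc(-c2cc(C(=O)O)c3ccccc3n2)ccc1OCC(=O)Nc1ccccc1C`, 0.8
compound 3, `COc1cc(-c2cc(C(=O)O)c3ccccc3n2)ccc1OCC(=O)Nc1cccc(C)c1`, 1.5

All values come from a physicochemical assay for lipophilicity, using the shake flask method, in phosphate buffer, measured as octanol-water partition, at pH 7.4; a lower number here means a more polar compound, a higher number a more lipophilic compound. Compound 2 stands second highest of the three numbers; compound 1 lies within the scatter of it, and only compound 3 sits clearly apart, as the step of a number 0.70 log units higher from compound 2 to compound 3 (beyond the scatter) shows. Compound 4, `COc1cc(-c2cc(C(=O)O)c3ccccc3n2)ccc1OCC(=O)Nc1ccccc1F`, differs from compound 2 by fluoro in place of methyl on an aromatic carbon. The step bearing most directly on it is a number 0.10 log units higher from compound 1 to compound 2 (within the scatter), which puts hydrogen against methyl at the same place and stays within the scatter; a number 0.80 log units higher from compound 1 to compound 3 (beyond the scatter) concerns a different place and is not comparable. Since methyl added nothing measurable there, exchanging it for fluoro is expected to move little: the step of a number 0.10 log units lower from compound 2 to compound 4 (within the scatter) is estimated as none beyond the scatter. Compound 4 is expected to give 0.7, between 0.3 and 1.1.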

Compound 4, distribution coefficient: 0.9
Compound 4: the middle estimate sits 0.20 log units below what was measured, within the range that was stated.
By their numbers in this assay, from the lowest: compounds 1, 2 and 4 (each within the scatter of the next); then compound 3.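

With fluoro in place of methyl at this place (a number 0.10 log units higher from compound 2 to compound 4 (within the scatter)) and fluoro in place of hydrogen (a number 0.20 log units higher from compound 1 to compound 4 (within the scatter)), this assay separates none of the three groups tried on this aromatic carbon. Only compound 3 remains apart, with its 3-methylphenyl (a number 0.60 log units lower from compound 3 to compound 4 (beyond the scatter)). Nothing at hand gives a reason for this pattern.

As far as these compounds go, whether an amine or a nitrile at this place would move the number beyond the scatter stays open. Also open, from the compounds shown here alone, is whether fluoro in place of the methyl of compound 3 would keep that compound's separation.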